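The source may report more compounds than this note shows. Statements on the series, on what has been measured and on what is new or still open speak of the compounds shown alone.

Compound 1 `O=C1NC(=O)/C(=C/C2=Cc3ccccc3OC2)S1`: in an ADME assay on NIH3T3 cells (Mus musculus) for antiproliferative activity, read by MTT assay, with a stated time of 72 h (a higher number here means a weaker inhibitor, a lower number a stronger inhibitor), compound 1 gives only a limit of the assay, > 200000 nM, not a number.
Compound 2 `CN1C(=O)S/C(=C\C2=Cc3ccccc3OC2)C1=O`: in this assay compound 2 gives "not determined" (no result reported).
Compound 3 `CCN1C(=O)S/C(=C\C2=Cc3ccccc3OC2)C1=O`: in this assay compound 3 gives "not determined" (no result reported).

Within the data shown here, compound 1 thus stands at the weak end of what was tried: its result is the cut-off of the measurement, (the limit of > 200000 nM in this assay, at which 1 of the 3 values shown sits), and the two other compounds bring no number beside it, so no step between measured compounds can be read. Compound 4 `O=C1NC(=O)/C(=C/C2=Cc3cc(Br)ccc3OC2)S1` differs from compound 1 by bromo in place of hydrogen on an aromatic carbon. Among the measured compounds shown here, with no measured step to lean on, the change is expected to stay within the usual scatter, in no fixed direction. The step is expected to be a number no higher from compound 1 to compound 4 (the limit leaves the size open). Compound 4 is therefore estimated at 200000 nM, in a range from 40000 nM to 400000 nM, and it will most likely come back as a limit rather than a number.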

Compound 4, half-maximal inhibitory concentration: 56500 nM
For compound 4 the middle estimate is 3.5-fold (0.55 log units) above the measured one; the measured number falls inside the stated range.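

Bromo in place of hydrogen at this aromatic carbon brings an at least 3.5-fold lower number from compound 1 to compound 4 (0.54 log units; beyond the scatter) in this assay, so this change gives a stronger inhibitor and the first true number among the compounds shown. The steps involving compound 2 and compound 3 cannot be read. From the compounds shown here alone, compound 1 gives only a limit, not a number, so the full size of the step stays unknown: the limit of > 200000 nM in this assay, at which 1 of the 4 values shown sits.

Going by these compounds, whether chloro, methoxy or an amine at the same carbon would lower the number as well remains open. So does the effect of bromo on another carbon of that ring.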